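The source may hold more compounds than are shown below. What is called first, only, known or untested is meant among the compounds shown, and "the series" means these compounds.

Of the compounds shown here, three of one family have been tested in an in vitro functional assay on HEK285-7 cells for antagonist activity at prostaglandin D2 receptor 2 (Homo sapiens), read by BRET and beta-arrestin recruitment; on this read-out lower numbers stand for stronger inhibition and higher numbers for weaker inhibition. Compound 1 `O=C(O)Cc1sc(C(c2ccccc2)c2ccccn2)nc1-c1ccc(Cl)cc1` gives 1900 nM. Compound 2 `O=C(O)Cc1sc(C(c2ccccc2)c2ccccc2)nc1-c1ccc(F)c(F)c1` gives 43 nM. Compound 3 `CS(=O)(=O)Nc1cccc(-c2nc(C(c3ccc(F)cc3)c3ccc(F)cc3)sc2CC(=O)O)c1` gives 370 nM, which places compound 3 second highest of the three numbers: compound 1 shows a higher number than compound 3, a gap beyond the usual scatter, while compound 2 shows a lower number than compound 3, a gap also beyond the scatter. All three share a core that carries a carboxymethyl group and a large group on the five-membered aromatic ring.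

Compound 4 `O=C(O)Cc1sc(C(c2ccc(F)cc2)c2ccc(F)cc2)nc1-c1ccnc(N2CCCC2)c1` has not yet been measured in this assay. It differs from compound 3 in one place:

2-(pyrrolidin-1-yl)pyridin-4-yl in place of 3-(methanesulfonamido)phenyl on an aromatic carbon

Within the data shown here, no measured pair shows this change, so its effect is open. Compound 3 is expected to set the starting point, and a modest step toward a lower number is anticipated from compound 3 to compound 4, roughly a 1.9-fold lower number from compound 3 to compound 4 (0.27 log units; within the scatter), a step that may not clear the scatter. The estimate for compound 4 in this assay is 200 nM, expected to fall between 40 nM and 1000 nM.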

Compound 4, half-maximal inhibitory concentration: > 100000 nM
Compound 4 ended at the assay's limit; the forecaster's own chance of this, stated with the estimate: 5%; middle value at least 500-fold (2.69 log units) away from the limit.
By their numbers in this assay, from the lowest: compound 2; then compound 3; then compound 1. At a limit, above all of these: compound 4.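

In this assay, among these compounds, putting 2-(pyrrolidin-1-yl)pyridin-4-yl in place of 3-(methanesulfonamido)phenyl, on the aromatic carbon next to the ring nitrogen and next to the ring atom that bears the carboxymethyl group, gives an at least 270-fold higher number from compound 3 to compound 4 (2.43 log units; beyond the scatter), the first reading of a single change in this family, since the earlier compounds differ from one another in more than one place. The outgoing and incoming groups have the same count of heavy atoms and hydrogen-bond acceptors and neither carries a net charge, so this position clearly does not accept every group that matches on those counts. The reading for compound 4, > 100000 nM, is a limit of the assay and not a number, so the step gives only the smallest possible size of the change: the limit of > 100000 nM in this assay, at which 1 of the 4 values shown sits.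

Still open, on these data alone, is which part of the swap matters, as it removes the methanesulfonamido group and its hydrogen-bond donor, brings in a ring nitrogen and adds a pyrrolidine all at once. A plain pyridin-4-yl group or a 3-(pyrrolidin-1-yl)phenyl group at this position would help to separate these three changes.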